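The source may hold more compounds than are shown below. What is called first, only, known or untested is meant among the compounds shown, and "the series" means these compounds.

Measured compounds:
- compound 1, `CCCCNC(=O)CC1CCc2cc(OC)c(OC)cc21`: 39.4%
- compound 2, `CCCCCNC(=O)CC1CCc2cc(OC)c(OC)cc21`: 71.7%
- compound 3, `COc1cc2c(cc1OC)C(CC(=O)N1CCCC1)CC2`: 19.2%

In a functional assay on the whole organism (strain Swiss albino) for inhibition, with Mus musculus as the target, in the writhing test, with stated times of 60 min and 15 min, at a dose of 100 mg/kg by the oral route (a lower number here means less inhibition, a higher number more inhibition at the dose given (going by the name of the read-out)), compound 3 gives the lowest of the three numbers; compound 1 stands nearest, and the step is a number 20.2 percentage points lower from compound 1 to compound 3 (beyond the scatter), while compound 2 stands furthest, with the step of a number 52.5 percentage points lower from compound 2 to compound 3 (beyond the scatter). Both measured steps that reach compound 3 replace an open-chain amino group on the carbonyl carbon by a ring, and both lower the inhibition in this assay beyond the scatter. The step from compound 1 to compound 2, a number 32.3 percentage points higher from compound 1 to compound 2 (beyond the scatter), concerns only the length of the chain and does not touch the ring.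

Compound 4, `COc1cc2c(cc1OC)C(CC(=O)N1CCOCC1)CC2`, differs from compound 3 as follows: morpholin-4-yl in place of pyrrolidin-1-yl on a carbonyl carbon. Among the compounds with values here, no measured step exchanges one such ring for another, so the two ring-to-chain steps serve only to show that compound 3 already sits at the low end. Compound 4 is therefore expected to stay near compound 3, with a step of a number 4.2 percentage points lower from compound 3 to compound 4 (within the scatter) that is estimated not to exceed the scatter. The estimate for compound 4 in this assay is 15%, within a range from 0% to 35%.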

Compound 4, a percentage reported as inhibition, in the whole organism at one dose (the size of the read-out at that dose, not a potency): 23.6%
The estimate for compound 4 lay 8.6 percentage points below the measured number; the measured number falls inside the stated range.
By their numbers in this assay, from the lowest: compounds 3 and 4 (each within the scatter of the next); then compound 1; then compound 2.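

Within the data shown here, until now no measured step had exchanged one ring on the carbonyl carbon for another. In this assay this exchange gives a number 4.4 percentage points higher from compound 3 to compound 4 (within the scatter), so the ring oxygen and hydrogen-bond acceptor that morpholin-4-yl brings make no difference that can be read from pyrrolidin-1-yl at this position. Morpholin-4-yl also stands apart from both open chains on the same carbonyl carbon, with a number 48.1 percentage points lower from compound 2 to compound 4 (beyond the scatter) and a number 15.8 percentage points lower from compound 1 to compound 4 (beyond the scatter), and nothing at hand bears on the reason for this result.

From the compounds shown here alone, whether the low numbers go with a ring as such or with the loss of the amide hydrogen stays open, and an open-chain diethylamino group on the carbonyl carbon would separate the two. Also open, going by these compounds, is where a piperidin-1-yl or piperazin-1-yl ring, or a hexylamino chain, would fall.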